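Replacing the carbonyl-linked group of compound 3

The source may report more compounds than this note shows. Statements on the series, on what has been measured and on what is new or still open speak of the compounds shown alone.

Measured so far in a functional assay on HCT-116 cells (Homo sapiens) for inhibition; on this read-out lower numbers stand for an effect already at smaller amounts and higher numbers for an effect only at larger amounts of compound
- compound 1 `COc1cc(N2CCN(C(=O)C3CCC(O)CC3)CC2)ccc1Nc1nc(NC2CCCCC2)c2nc[nH]c2n1` gives 14 nM
- compound 2 `COc1cc(N2CCN(Cc3ccccn3)CC2)ccc1Nc1nc(NC2CCCCC2)c2nc[nH]c2n1` gives 89 nM
- compound 3 `COc1cc(N2CCN(C(=O)N3CCC(O)C3)CC2)ccc1Nc1nc(NC2CCCCC2)c2nc[nH]c2n1` gives 100 nM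

The data show a 1.1-fold higher number from compound 2 to compound 3 (0.05 log units; within the scatter) and also a 7.1-fold higher number from compound 1 to compound 3 (0.85 log units; beyond the scatter) on the other side, so compound 3 pairs with compound 2 and stands clear of compound 1. Compound 4 `COc1cc(N2CCN(CC3CCOC3)CC2)ccc1Nc1nc(NC2CCCCC2)c2nc[nH]c2n1` carries (oxolan-3-yl)methyl in place of (3-hydroxypyrrolidin-1-yl)carbonyl on an amine nitrogen in a ring. The closest guide carries (pyridin-2-yl)methyl on that nitrogen, and there a 1.1-fold higher number from compound 2 to compound 3 (0.05 log units; within the scatter) stays within the scatter. A similar swap elsewhere gave a 6.4-fold higher number from compound 1 to compound 2 (0.80 log units; beyond the scatter) however, so the range stays wide. An expected step of a 1.1-fold lower number from compound 3 to compound 4 (0.05 log units; within the scatter) follows, none beyond the scatter. For compound 4 an estimated 90 nM is expected, within an estimated range of 30 nM to 270 nM in this read-out.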

Compound 4, half-maximal effective concentration: 170 nM
Beside the measured number, compound 4's estimate is 1.9-fold (0.28 log units) below it; the measured number falls inside the stated range.
By their numbers in this assay, from the lowest: compound 1; then compounds 2, 3 and 4 (each within the scatter of the next).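

With this assay as the read-out, the step of a 1.7-fold higher number from compound 3 to compound 4 (0.23 log units; within the scatter) stays within the scatter, even though the entering (oxolan-3-yl)methyl carries 0 hydrogen-bond donors and no carbonyl. Exchanging the ring on the methyl link gives a 1.9-fold higher number from compound 2 to compound 4 (0.28 log units; within the scatter) and also stays within the scatter. Against the carbonyl-linked 4-hydroxycyclohexyl, the change gives a 12-fold higher number from compound 1 to compound 4 (1.08 log units; beyond the scatter) and so, of these four compounds, only compound 1 stands apart at this amine nitrogen.

From the compounds shown here alone, whether its hydroxyl or its six-membered ring sets compound 1 apart stays open, as does where a simple acetyl or a 4-hydroxycyclohexylmethyl group on this nitrogen would fall. Nothing measured here gives a reason for these steps.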